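Amide side chain: basic amine versus carboxylic acid

The source may hold more compounds than are shown below. What is called first, only, known or untested is meant among the compounds shown, and "the series" means these compounds.

The series keeps one core, seen in compound 1 `CCn1c(C(=O)NCCC(=O)OC)ccc1C(CC)(CC)c1ccc(C#CC(O)(CC)CC)c(C)c1`, and varies only the group on the amide carbonyl. In a functional assay on MCF7 cells (Homo sapiens) for antiproliferative activity, read by MTT assay, with a stated time of 72 h (on this read-out higher numbers stand for weaker inhibition and lower numbers for stronger inhibition), compound 1 gives > 50000 nM, which is a limit of the assay rather than a number. Among the measured compounds shown here, compound 2 `CCN(CC)CCCNC(=O)c1ccc(C(CC)(CC)c2ccc(C#CC(O)(CC)CC)c(C)c2)n1CC` is the only member with a measured number, giving 17800 nM in this assay. Compound 3 `CCn1c(C(=O)On2nnc3ccccc32)ccc1C(CC)(CC)c1ccc(C#CC(O)(CC)CC)c(C)c1` gives > 50000 nM in this assay, again a limit. For the measured compounds named here, two of the three values therefore sit at the limit of > 50000 nM in this assay, at which 2 of the 3 values shown sit, so only one step is readable in full: an at least 2.8-fold lower number from compound 1 to compound 2 (0.44 log units; beyond the scatter). The remaining comparisons give an at least 2.8-fold higher number from compound 2 to compound 3 (0.44 log units; beyond the scatter) and a step that the two limits leave unreadable from compound 1 to compound 3.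

Compound 4 `CCn1c(C(=O)NCCC(=O)O)ccc1C(CC)(CC)c1ccc(C#CC(O)(CC)CC)c(C)c1` carries the change (carboxy in place of (diethylamino)methyl on a saturated chain carbon, two bonds along the chain from an amide-type nitrogen). The step that bears on it is the one from compound 1 to compound 2, where methoxycarbonyl gave way to (diethylamino)methyl and the number fell by at least the amount shown. Compound 4 returns to a carboxy group on that same chain carbon, closer to the ester of compound 1 than to the amine of compound 2, so the number is expected to rise again, with a good chance of landing back at the limit. The expected step is a 2.5-fold higher number from compound 2 to compound 4 (0.40 log units; beyond the scatter). Compound 4 is estimated at 45000 nM, within 15000 nM to 150000 nM.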

Compound 4, half-maximal inhibitory concentration: > 50000 nM
Compound 4: a limit, no number; the forecaster's own chance of this, stated with the estimate: 55%; at least 1.1-fold (0.04 log units) between middle value and limit.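

Exchanging (diethylamino)methyl for carboxy on the saturated chain carbon, two bonds along the chain from an amide-type nitrogen, gives an at least 2.8-fold higher number from compound 2 to compound 4 (0.44 log units; beyond the scatter). Together with the earlier step from the ester, this means that two different oxygen-bearing groups at this place, methoxycarbonyl in compound 1 and carboxy in compound 4, both fall short of the only measured number in the series, held by the (diethylamino)methyl group of compound 2, and the free acid brings no readable recovery over the ester. In this assay compound 4 gives > 50000 nM, a limit of the assay and not a number, and the steps from compound 1 and from compound 3 to compound 4 cannot be read, so the series now rests on one number and this limit: the limit of > 50000 nM in this assay, at which 3 of the 4 values shown sit.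

Still open, on these data alone, is whether the number of compound 2 depends on the diethylamino group itself or would hold for another amine at the chain end, such as a dimethylamino group, a piperidine or a primary amine. Also open, as far as these compounds go, is how a shorter or longer chain between the amide nitrogen and that amine would read in this assay.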